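This account rests on a few compounds, and the source may have more. Where it says the series, first, only, none or still open, it means among the compounds named here.

Working notes on the series. In a functional assay on HCT-116 cells (Homo sapiens) for inhibition, read by MTT assay, with a stated time of 48 h (on this read-out higher numbers stand for weaker inhibition and lower numbers for stronger inhibition), compound 1 `CCSc1nnc(-c2cc(OC)c(OC)c(OC)c2)n1-c1ccc(OC)cc1` gives > 60000 nM, which is a limit of the assay. Compound 2 `COc1ccc(-n2c(SCc3ccccc3)nnc2-c2cc(OC)c(OC)c(OC)c2)cc1` gives 42400 nM. Compound 3 `COc1ccc(-n2c(SCC(=O)c3ccc(OC)c(O)c3)nnc2-c2cc(OC)c(OC)c(OC)c2)cc1` gives > 60000 nM, also only a limit, and so stands at the limit of > 60000 nM in this assay, at which 2 of the 3 values shown sit.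

Compound 4 `COc1ccc(-n2c(SCC(=O)C3CC3)nnc2-c2cc(OC)c(OC)c(OC)c2)cc1` carries cyclopropyl in place of 3-hydroxy-4-methoxyphenyl on a carbonyl carbon.

The measured steps on the group carried by the sulfur-bound chain carbon give little guidance. The step of an at least 1.4-fold lower number from compound 1 to compound 2 (0.15 log units; that floor lies within the scatter) stays within the scatter, as does an at least 1.4-fold higher number from compound 2 to compound 3 (0.15 log units; that floor lies within the scatter), while a step that the two limits leave unreadable from compound 1 to compound 3 cannot be sized. In this assay, no step beyond the scatter is therefore expected, in either direction. The estimate means an at least 1.2-fold lower number from compound 3 to compound 4 (0.07 log units; that floor lies within the scatter), as an expected step. Compound 4 is estimated at 50000 nM, with an expected range of 20000 nM to 120000 nM.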

Compound 4, half-maximal inhibitory concentration: > 60000 nM
Compound 4 was reported as a limit; the forecaster's own chance of this, stated with the estimate: 50%; at least 1.2-fold (0.07 log units) between middle value and limit.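

With cyclopropyl in place of 3-hydroxy-4-methoxyphenyl on the carbonyl carbon, compound 4 still gives only a limit in this assay, so neither carbonyl compound shown yields a numerical value. Among the compounds shown here, the one readable step is an at least 1.4-fold higher number from compound 2 to compound 4 (0.15 log units; that floor lies within the scatter), while the steps from compound 3 and from compound 1 to compound 4 cannot be read. The series thus remains mostly at: the limit of > 60000 nM in this assay, at which 3 of the 4 values shown sit.

On these data alone, how far compound 1, compound 3 and compound 4 lie apart stays open. Also open, as far as these compounds go, is whether an amine or a carboxylic acid on the sulfur-bound chain would give a step beyond the scatter.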